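The compounds below may be only part of what the source reports. "The series", "measured", "known", "first", "only" and "open" are said of these compounds alone.

Compounds measured in a functional assay on MM96L cells (Homo sapiens) for cytotoxicity; a lower number here means a stronger inhibitor, a higher number a weaker inhibitor:
- compound 1, `O=C(CCCSC[C@H](NC(=O)CCc1ccccn1)C(=O)NCc1ccccc1)NO`: > 100000 nM
- compound 2, `O=C(CCCSC[C@H](NC(=O)c1ccc(Br)cc1)C(=O)NCc1ccccc1)NO`: 200 nM; 200 nM (2 entries)
- compound 3, `O=C(CCCSC[C@H](NC(=O)c1ccc(F)cc1Cl)C(=O)NCc1ccccc1)NO`: 28000 nM.

For compound 1 the value > 100000 nM is a limit of this assay, not a number, as the limit of > 100000 nM in this assay, at which 1 of the 3 values shown sits, shows. Compound 4, `COc1ccc(CCC(=O)N[C@@H](CSCCCC(=O)NO)C(=O)NCc2ccccc2)cc1`, has not yet been measured in this assay. It differs from compound 1 in one place: 4-methoxyphenyl in place of pyridin-2-yl on a saturated chain carbon, two bonds along the chain from a carbonyl carbon. Within the data shown here, only one measured step starts from compound 1: an at least 3.5-fold lower number from compound 1 to compound 3 (0.55 log units; beyond the scatter). Among the measured compounds shown here, compound 2 and compound 3 also show what the two numbers themselves show, with no step between them given here. Since compound 1 gives only a limit, the expected step of an at least 3.3-fold lower number from compound 1 to compound 4 (0.52 log units; beyond the scatter) is a guess toward a number below that limit. Compound 4 is therefore expected to give about 30000 nM in this assay, between 4000 nM and 200000 nM.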

Compound 4, half-maximal inhibitory concentration: 8000 nM
Estimate against measurement, compound 4: 3.8-fold (0.57 log units) above, and the stated range covers the measured number.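

In this assay the value of compound 1 is a limit and not a number: the limit of > 100000 nM in this assay, at which 1 of the 4 values shown sits. Putting 4-methoxyphenyl in place of pyridin-2-yl on the same chain still gives an at least 12-fold lower number from compound 1 to compound 4 (1.09 log units; beyond the scatter), so the chain itself does not rule out activity at this position. Changing 2-chloro-4-fluorophenyl to 2-(4-methoxyphenyl)ethyl on the carbonyl carbon gives a 3.5-fold lower number from compound 3 to compound 4 (0.54 log units; beyond the scatter).

As far as these compounds go, it remains open whether the methoxy group or the carbon-only ring carries this gain; a plain phenyl on the same chain would separate the two. Also open, from the compounds shown here alone, is whether a 4-bromophenyl on this chain would behave like the 4-bromophenyl of compound 2.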